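This account rests on a few compounds, and the source may have more. Where it says the series, first, only, none or still open, it means among the compounds named here.

Within the data shown here, in a functional assay on MCF7 cells (Homo sapiens) for antiproliferative activity, read by MTT assay, with a stated time of 72 h (a higher number here means a weaker inhibitor, a lower number a stronger inhibitor), compound 1 (`O=C(N/N=C/c1ccc(Br)cc1)Nc1ccc(Oc2ccnc3[nH]ccc23)c(F)c1`) gives 930 nM, the only number so far. In this assay compound 2 (`N#Cc1ccc(/C=N/NC(=O)Nc2ccc(Oc3ccnc4[nH]ccc34)c(F)c2)cc1`) gives "not active" (no number reported). In the same assay, compound 3 (`O=C(N/N=C/c1cccc(Cl)c1Cl)Nc1ccc(Oc2ccnc3[nH]ccc23)c(F)c1`) gives "not active" (no number reported). Compound 3 therefore stands with compound 2 among the entries without a number, and no numerical gap to compound 1 can be stated.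

Compound 4 (`O=C(N/N=C/c1ccc(Cl)c(Cl)c1)Nc1ccc(Oc2ccnc3[nH]ccc23)c(F)c1`) keeps the shared core and differs from compound 3 only in the arrangement of the two chlorines: 3,4-dichlorophenyl in place of 2,3-dichlorophenyl on a carbon with a double bond to nitrogen. In words, 3,4-dichlorophenyl stands in place of 2,3-dichlorophenyl on a carbon with a double bond to nitrogen.

Among the measured compounds shown here, no measured pair differs in one place, so the data offer no step to scale this change against. The expected direction in this assay is toward stronger inhibition, from no reported number to a measurable one, but the size of that step cannot be given while compound 3 lacks a number. For the measured compounds named here, the only numerical anchor is compound 1 at 930 nM, and a second "not active" result remains a real possibility, given the outcomes for compound 2 and compound 3. Compound 4 is estimated at 1500 nM, with an expected range of 500 nM to 5000 nM.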

Compound 4, half-maximal inhibitory concentration: 998 nM
Compound 4: middle estimate off by 1.5-fold (0.18 log units), on the high side, and the stated range covers the measured number.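

In this assay, moving the two chlorines on the carbon with a double bond to nitrogen separates an entry without a number from a measured one: compound 3, with 2,3-dichlorophenyl, has no number, whereas compound 4, with 3,4-dichlorophenyl and the same atoms, gives 998 nM. Replacing 4-bromophenyl with 3,4-dichlorophenyl gives a 1.1-fold higher number from compound 1 to compound 4 (0.03 log units; within the scatter), so this exchange is not told apart in this assay, while steps to or from compound 2 or compound 3 cannot be read as sizes, as neither compound has a number. No measured information available here bears on why the arrangement of the chlorines matters.

As far as these compounds go, whether either chlorine of 3,4-dichlorophenyl is needed for a measurable result remains open, as an unsubstituted phenyl or a monochlorophenyl at the same place would be required to test it. From the compounds shown here alone, how a methoxyphenyl or an aminophenyl would behave in this assay also remains open, so the range of groups compatible with a measured number at this position is still undefined.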